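The compounds below may be only part of what the source reports. "The series", "measured", "known", "first", "only" and "open" are said of these compounds alone.

Compound 1 `Brc1cn2ccnc2c(-c2ccc3ncn(C4CCCCC4)c3c2)n1`: 18%
Compound 2 `CCc1ccc(-c2cn3ccnc3c(-c3ccc4ncn(Cc5ccccc5)c4c3)n2)cc1`: 39.6%

In a functional assay on HL-60 cells (Homo sapiens) for inhibition, read by sulforhodamine B assay, with a stated time of 48 h, tested at 10 uM (a higher number here means more inhibition at the concentration tested (going by the name of the read-out), a lower number less inhibition), compound 1 gives 18%, while compound 2 gives 39.6%, the higher of the two numbers and beyond the scatter of the other. Compound 3 `Cc1cccc(-c2cn3ccnc3c(-c3ccc4ncn(Cc5ccccc5)c4c3)n2)c1` has not yet been measured. It differs from compound 2 in one place: 3-methylphenyl in place of 4-ethylphenyl on an aromatic carbon. For the measured compounds named here, no measured pair shows a change of this kind, so the step is expected to be small, a number 6.6 percentage points lower from compound 2 to compound 3 (within the scatter), a slight decline that may stay within the scatter. Compound 3 is therefore estimated at 33%, with a range from 15% to 50%.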

Compound 3, a percentage reported as inhibition, at one concentration (the size of the read-out at that concentration, not a potency): 18.2%
Compound 3: the middle estimate sits 14.8 percentage points above what was measured; low and high end bracket the measured number.
By their numbers in this assay, from the lowest: compounds 1 and 3 (each within the scatter of the next); then compound 2.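

In this assay, 3-methylphenyl in place of 4-ethylphenyl on this aromatic carbon gives a number 21.4 percentage points lower from compound 2 to compound 3 (beyond the scatter). For the compounds shown here, this is the first one-place comparison, and it shows that inhibition at the concentration tested responds to a change confined to the aryl group at this position. No measurement on hand accounts for the step.

The change alters both the alkyl group and its place on the phenyl ring, and these two remain unseparated. On these data alone, how 4-methylphenyl or 3-ethylphenyl would read at this carbon stays open.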